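Adding a methyl to the piperidin-1-yl of compound 2

The compounds below may be only part of what the source reports. "The series", "measured", "known", "first", "only" and "open" are said of these compounds alone.

Of the compounds shown here, three sharing one core have been tested in a functional assay on HT-29 cells (Homo sapiens) for cytotoxicity, read by MTT assay, with a stated time of 72 h; on this read-out lower numbers stand for stronger inhibition and higher numbers for weaker inhibition. Compound 1 `COc1cc2c(Oc3ccc(NC(=O)N/N=C/c4ccc(F)cc4Cl)cc3F)ccnc2cc1OCCCN1CCCCC1` gives 260 nM. Compound 2 `COc1cc2c(Oc3ccc(NC(=O)N/N=C/c4ccc(Cl)cc4Cl)cc3F)ccnc2cc1OCCCN1CCCCC1` gives 370 nM, and compound 3 `C=CCc1cccc(/C=N/NC(=O)Nc2ccc(Oc3ccnc4cc(OCCCN5CCCCC5)c(OC)cc34)c(F)c2)c1OC` gives 460 nM. Compound 2 holds the second highest of the three numbers: the step of a 1.4-fold higher number from compound 1 to compound 2 (0.15 log units; within the scatter) comes from a chloro in place of a fluoro on an aromatic carbon, and the step of a 1.2-fold higher number from compound 2 to compound 3 (0.09 log units; within the scatter) comes from a 3-allyl-2-methoxyphenyl in place of a 2,4-dichlorophenyl on the carbon with a double bond to nitrogen, and both lie within the scatter, as does a 1.8-fold higher number from compound 1 to compound 3 (0.25 log units; within the scatter).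

Compound 4 `COc1cc2c(Oc3ccc(NC(=O)N/N=C/c4ccc(Cl)cc4Cl)cc3F)ccnc2cc1OCCCN1CCC(C)CC1` is not yet measured. It differs from compound 2 by methyl in place of hydrogen on a saturated ring carbon. For the measured compounds named here, none of the measured steps touches the saturated ring; all three change the aryl group on the carbon with a double bond to nitrogen, and each stays within the scatter. Going by the values given here, the data therefore give no step that speaks directly to the change from compound 2 to compound 4, and no direction can be read from them.

Compound 4 is accordingly expected to sit near compound 2 in this assay, at 370 nM, within a range of 150 nM to 900 nM. The expected step of no change at the digits printed from compound 2 to compound 4 (within the scatter) is therefore estimated to stay within the scatter.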

Compound 4, half-maximal inhibitory concentration: 470 nM
Compound 4: the middle estimate sits 1.3-fold (0.10 log units) below what was measured; the range from low to high includes it.
By their numbers in this assay, from the lowest: compounds 1, 2, 3 and 4 (each within the scatter of the next).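

In this assay, the step of a 1.3-fold higher number from compound 2 to compound 4 (0.10 log units; within the scatter) is the only one in this set that touches the saturated ring; every earlier step changed an aryl group on the carbon with a double bond to nitrogen and left the piperidin-1-yl as it was. It shows that a methyl can stand on this ring carbon, three ring bonds from the ring nitrogen, without moving the number beyond the scatter, so this read-out does not separate 4-methylpiperidin-1-yl from piperidin-1-yl in this pair. No measurement of any other kind is available to bear on this result.

The compounds shown leave open whether a larger or functionalised group on the same ring carbon, such as an ethyl, a hydroxyl or a carboxylic acid, or a morpholin-4-yl in place of the whole piperidin-1-yl, would also stay within the scatter. They also leave open whether the methyl gives a step of similar size when paired with the aryl groups of compound 1 or compound 3, since it is seen here only with the aryl group of compound 2.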